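From open chain to closed ring: compound 3 to compound 4

The source may hold more compounds than are shown below. What is called first, only, known or untested is meant among the compounds shown, and "the series" means these compounds.

Compound 1: `C/N=C(\N)Nc1nnc(-c2ccccc2C(F)(F)F)s1`, in a functional assay on the whole organism (Hindlimb) for inhibition, with Mus musculus as the target, in the maximal electroshock model, with a stated time of 1 h (a higher number here means that more compound is needed for the effect, a lower number that less compound is needed), compound 1 gives 49 mg/kg.
Compound 2: `CCCC/N=C(\N)Nc1nnc(-c2ccccc2C(F)(F)F)s1`, compound 2 gives 142 mg/kg.
Compound 3: `COCCC/N=C(\N)Nc1nnc(-c2ccccc2C(F)(F)F)s1`, compound 3 gives only a limit, > 100 mg/kg.

Compound 3 thus stands at the limit of this assay, (the limit of > 100 mg/kg in this assay, at which 1 of the 3 values shown sits), and where it sits relative to the other two cannot be read beyond that. Among the measured steps, a 2.9-fold higher number from compound 1 to compound 2 (0.46 log units; beyond the scatter), while an at least 2.0-fold higher number from compound 1 to compound 3 (0.30 log units; that floor lies within the scatter), and a step that the limit leaves unreadable from compound 2 to compound 3. Compound 4, `FC(F)(F)c1ccccc1-c1nnc(NC2=NCCN2)s1`, differs from compound 3 in that (a group of 5 heavy atoms (3 carbon, 2 nitrogen; one five-membered non-aromatic ring with 2 hetero atoms) in place of a group of 8 heavy atoms (5 carbon, 2 nitrogen, 1 oxygen; no ring), on a nitrogen on an aromatic ring). For the measured compounds named here, no measured step closes this chain into a ring, so none bears directly on it; the two steps from compound 1 show only that the propyl chain raises the dose. Compound 4 is therefore expected, with wide uncertainty, to lie nearer compound 1, an estimated 60 mg/kg (range 25 mg/kg to 150 mg/kg), which would mean an at least 1.6-fold lower number from compound 3 to compound 4 (0.22 log units; that floor lies within the scatter).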

Compound 4, dose for half-maximal effect: > 100 mg/kg
Compound 4: only a limit was reported; the forecaster's own chance of this, stated with the estimate: 35%; at least 1.6-fold (0.22 log units) between middle value and limit.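

In this assay compound 4, with its five-membered non-aromatic ring on the nitrogen, gives > 100 mg/kg, a limit of the assay, so closing the ring yields no measured dose either: the limit of > 100 mg/kg in this assay, at which 2 of the 4 values shown sit. For the compounds shown here, the one readable step is an at least 2.0-fold higher number from compound 1 to compound 4 (0.30 log units; that floor lies within the scatter). The steps from compound 2 and compound 3 to compound 4 cannot be read.

As far as these compounds go, how far the true doses of compound 3 and compound 4 lie past this limit remains open. So does whether a six-membered ring, or an amine on the five-membered ring, would give a measurable dose.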